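The source may report more compounds than this note shows. Statements on the series, on what has been measured and on what is new or still open speak of the compounds shown alone.

In a functional assay on a cell-free system (plasma, Homo sapiens) for inhibition, with Plasma (Rattus norvegicus) as the target (a higher number here means a weaker inhibitor, a lower number a stronger inhibitor), compound 1 (`O=c1cc(N2CCNCC2)oc2ccccc12`) gives 240000 nM and compound 2 (`Cc1c(OCc2cccnc2)ccc2c(N3CCNCC3)cc(=O)oc12`) gives 1420 nM as the lower of the two numbers, a gap that lies beyond the scatter. Compound 3 (`COCOc1ccc2c(N3CCNCC3)cc(=O)oc2c1C`) has not yet been measured. Its structure departs from that of compound 2 in one place. The change is methoxy in place of pyridin-3-yl on a saturated chain carbon bound to an oxygen on an aromatic ring in words: methoxy in place of pyridin-3-yl on a saturated chain carbon bound to an oxygen on an aromatic ring. Among the compounds with values here, no measured step covers this change, so the expectation rests on the structural change alone. A moderate move to a higher number in this assay is expected, meaning a weaker inhibitor, though a result within the scatter cannot be excluded. An estimated 4.2-fold higher number from compound 2 to compound 3 (0.63 log units; beyond the scatter) is expected on this reasoning. For compound 3 the estimate is 6000 nM (expected range 1500 nM to 30000 nM).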

Compound 3, half-maximal inhibitory concentration: 3500 nM
Compound 3: middle estimate off by 1.7-fold (0.23 log units), on the high side; the measured number falls inside the stated range.
By their numbers in this assay, from the lowest: compound 2; then compound 3; then compound 1.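

In this assay, within the data shown here, this is the first step read at this position: a 2.5-fold higher number from compound 2 to compound 3 (0.39 log units; beyond the scatter), with methoxy in place of pyridin-3-yl on a saturated chain carbon bound to an oxygen on an aromatic ring. The change removes a six-membered aromatic ring with 1 hetero atom, yet the step remains modest, so that ring is not essential for inhibition in this pair, although its replacement does give a weaker inhibitor. Nothing available explains the size of this step.

From the compounds shown here alone, whether a phenyl ring on the same chain carbon would stand with compound 2 or with compound 3 remains open, which leaves the role of the ring nitrogen undecided. Also open, going by these compounds, is how a longer alkyl chain or a morpholine would read at this position.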